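The source may report more compounds than this note shows. Statements on the series, on what has been measured and on what is new or still open speak of the compounds shown alone.

Of the compounds shown here, three of a shared core have so far been measured in a functional assay on Ehrlich cells (Mus musculus) for cytotoxicity, tested at 50 ug/mL; on this read-out lower numbers stand for a weaker effect and higher numbers for a stronger effect at the one concentration tested. Compound 1 `COc1cc(N2C(N)=C(C#N)C(c3c(OC)ccc4ccccc34)C3=C2CC(C)(C)CC3=O)cc(OC)c1OC` gives 10% in this assay. Compound 2 `COc1cc(N2C(N)=C(C#N)C(c3cccc([N+](=O)[O-])c3)C3=C2CC(C)(C)CC3=O)cc(OC)c1OC` gives 30%. Compound 3 `COc1cc(N2C(N)=C(C#N)C(c3ccc(C)cc3)C3=C2CC(C)(C)CC3=O)cc(OC)c1OC` gives 60%, the highest of the three numbers; the nearest is compound 2 and the furthest compound 1, both beyond the scatter. The two steps among the measured compounds that end at compound 3 are a number 50 percentage points higher from compound 1 to compound 3 (beyond the scatter) and a number 30 percentage points higher from compound 2 to compound 3 (beyond the scatter), so every exchange of the group on the saturated ring carbon that has been tried moved this assay by a clear amount, and compound 3 carries the group that gave the strongest effect.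

Compound 4 `COc1cc(N2C(N)=C(C#N)C(c3cccs3)C3=C2CC(C)(C)CC3=O)cc(OC)c1OC` has not yet been measured. It differs from compound 3 in one place: thiophen-2-yl in place of 4-methylphenyl on a saturated ring carbon. Among the measured compounds shown here, no measured step exchanges the 4-methylphenyl for a thiophen-2-yl, so the expectation rests only on the spread seen when that position was varied. Because the steps of a number 50 percentage points higher from compound 1 to compound 3 (beyond the scatter) and a number 30 percentage points higher from compound 2 to compound 3 (beyond the scatter) show that other groups at this position sit well below compound 3, a downward step of modest size is expected here, with the estimated change being a number 20 percentage points lower from compound 3 to compound 4 (beyond the scatter). Compound 4 is therefore expected to give about 40% in this assay, within a range of 15% to 65%.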

Compound 4, a percentage reported as activity, at one concentration (the size of the read-out at that concentration, not a potency): 15%
Estimate against measurement, compound 4: 25 percentage points above; the range from low to high includes it.
By their numbers in this assay, from the lowest: compounds 1 and 4 (each within the scatter of the next); then compound 2; then compound 3.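

In this assay, thiophen-2-yl in place of 4-methylphenyl on the saturated ring carbon gives a number 45 percentage points lower from compound 3 to compound 4 (beyond the scatter), which shows that the effect of compound 3 does not carry over to this five-membered aromatic ring with its sulfur atom. The same position also gives a number 15 percentage points lower from compound 2 to compound 4 (beyond the scatter), so thiophen-2-yl falls short of 3-nitrophenyl as well, while a number 5 percentage points higher from compound 1 to compound 4 (within the scatter) leaves compound 4 and compound 1 indistinguishable, even though thiophen-2-yl is a much smaller group than 2-methoxynaphthalen-1-yl. Thus, among the four groups tried here, only 4-methylphenyl reaches the top of the range, and nothing measured alongside these values explains the loss on going to thiophen-2-yl.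

The compounds shown leave open whether the methyl group of 4-methylphenyl matters at all or whether the six-membered carbon ring alone is enough, a question that an unsubstituted phenyl or a 4-chlorophenyl at this position would address. They also leave open whether thiophen-3-yl or furan-2-yl would behave like thiophen-2-yl, and how the compounds would rank at other concentrations.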